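The source may report more compounds than this note shows. Statements on the series, on what has been measured and on what is new or still open speak of the compounds shown alone.

Measured in an ADME assay on microsomes from liver (Rattus norvegicus) for metabolic stability, read by LC-MS, with a stated time of 1 h, at 37 degrees C, tested at 4 uM; on this read-out higher numbers stand for a more stable compound and lower numbers for a less stable compound:
- compound 1 `O=C(O)c1ccc(Cl)c(-c2cccc(COc3ccc4c(c3)CN(C3CCCC3)C4=O)c2)c1` gives (15%)
- compound 2 `O=C(O)c1cc(-c2cccc(COc3ccc4c(=O)n(C5CCCC5)sc4c3)c2)ccc1F` gives (71%)
- compound 3 `O=C(O)c1cc(-c2cccc(COc3ccc4c(=O)n(C5CC5)sc4c3)c2)ccc1Cl` gives (86%)

Among these three, compound 2 (71%) stands second highest. Its gap to compound 3 (86%) and its gap to compound 1 (15%) are both beyond the scatter, with compound 3 on the higher side and compound 1 on the lower. Compound 1 carries a different core from compound 2, so its low value says little about a single change.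

The next compound to be read is compound 4 `Cc1ccc(C(=O)O)cc1-c1cccc(COc2ccc3c(=O)n(C4CCCC4)sc3c2)c1`. It keeps the core and the cyclopentyl-bearing framework of compound 2 and changes one group: 5-carboxy-2-methylphenyl in place of 3-carboxy-4-fluorophenyl on an aromatic carbon In words, 5-carboxy-2-methylphenyl stands in place of 3-carboxy-4-fluorophenyl on an aromatic carbon, meta to a large group.

Going by the values given here, no measured pair differs only at this place, so the data give no direct guide to the size of this step, and any forecast must stay wide. Compound 2 (71%) has much more room to fall than to rise on this scale, so a moderate fall is the likelier outcome. The expected change is an estimated (a number 16 percentage points lower from compound 2 to compound 4 (beyond the scatter)), which is only a little beyond the scatter. For compound 4 the estimated value in this assay is (55%), with an expected range (30% to 80%).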

Compound 4, percent of the compound remaining: 92%
Compound 4: middle estimate off by 37 percentage points, on the low side, and the stated range ends below it.
By their numbers in this assay, from the lowest: compound 1; then compound 2; then compounds 3 and 4 (each within the scatter of the next).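

In this assay, going by these compounds alone, the change to 5-carboxy-2-methylphenyl in place of 3-carboxy-4-fluorophenyl on an aromatic carbon, meta to a large group, gives the first readable step at this place (a number 21 percentage points higher from compound 2 to compound 4 (beyond the scatter)). With the shared core and the cyclopentyl group held fixed, this shows that the read-out can still rise from the level of compound 2 through a change in this aryl group alone, even though the heavy-atom count of the group stays the same and its hydrogen-bond donor and acceptor counts do not change. No measurement shown here accounts for the gain, so it stands as an observation without an explanation.

This single step replaces a fluorine and brings in a methyl group while also rearranging the substituents on the ring, so the compounds shown do not separate the part played by each of these differences. From the compounds shown here alone, whether an ethyl or a methoxy group would read like the methyl group, and whether the step would hold with the cyclopropyl group of compound 3 in place of the cyclopentyl group, remains open.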